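Working notes: from compound 3 to compound 4

This account rests on a few compounds, and the source may have more. Where it says the series, first, only, none or still open, it means among the compounds named here.

In a functional assay on HeLa cells (Homo sapiens) for cytotoxicity, read by MTT assay, with a stated time of 48 h (on this read-out higher numbers stand for weaker inhibition and lower numbers for stronger inhibition), compound 1 `CC1(C)CCC[C@]2(C)[C@@H](CC[C@@](C)(O)/C=C/c3ccccc3)[C@](C)(O)CC[C@@H]12` gives 3320 nM, and compound 2 `CC(C)(C)c1ccc(/C=C/[C@](C)(O)CC[C@@H]2[C@@]3(C)CCCC(C)(C)[C@@H]3CC[C@@]2(C)O)cc1` gives 48500 nM. Compound 3 `CC1(C)CCC[C@]2(C)[C@@H](CC[C@@](C)(O)/C=C/c3ccc(F)cc3)[C@](C)(O)CC[C@@H]12` gives 3460 nM, level with compound 1 within the scatter. The gap to the remaining compound is large: a 14-fold lower number from compound 2 to compound 3 (1.15 log units; beyond the scatter).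

Compound 4 `CC1(C)CCC[C@]2(C)[C@@H](CC[C@@](C)(O)/C=C/c3ccc(Oc4ccccc4)cc3)[C@](C)(O)CC[C@@H]12` differs from compound 3 by phenoxy in place of fluoro on an aromatic carbon. In words, this is phenoxy in place of fluoro on an aromatic carbon, para to a large group.

Among the compounds with values here, no measured step involves phenoxy, so only indirect guidance is available. Fluoro in place of hydrogen gives a 1.0-fold higher number from compound 1 to compound 3 (0.02 log units; within the scatter), which is within the scatter. Tert-butyl in place of hydrogen gives a 15-fold higher number from compound 1 to compound 2 (1.16 log units; beyond the scatter), which is large. Phenoxy resembles tert-butyl more than fluoro in being a large entering group, so the expectation leans on the compound 2 result, though that is a single example and the outcome is uncertain. A higher number is therefore expected in this assay, and the estimated step is a 4.0-fold higher number from compound 3 to compound 4 (0.61 log units; beyond the scatter), probably somewhat smaller than the tert-butyl step. For compound 4 the estimated value is 14000 nM, with an expected range from 4000 nM to 48000 nM.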

Compound 4, half-maximal inhibitory concentration: 3480 nM
The estimate for compound 4 lay 4.0-fold (0.60 log units) above the measured number; the whole stated range lies above it.
By their numbers in this assay, from the lowest: compounds 1, 3 and 4 (each within the scatter of the next); then compound 2.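

In this assay the size of the entering group does not by itself set the outcome on this aromatic carbon, para to a large group: the change to phenoxy, with its 7 heavy atoms and six-membered aromatic ring, gives a 1.0-fold higher number from compound 3 to compound 4 (0.00 log units; within the scatter) and, against the unsubstituted ring, a 1.0-fold higher number from compound 1 to compound 4 (0.02 log units; within the scatter), which leaves hydrogen, fluoro and phenoxy level with one another. Compound 2 alone now stands apart, as shown by a 14-fold lower number from compound 2 to compound 4 (1.14 log units; beyond the scatter), so tert-butyl goes against the otherwise flat picture across these four compounds, and a large group at this position is not enough to give a higher number. Nothing measured here accounts for the difference between tert-butyl and phenoxy.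

On these data alone, it remains open whether the tert-butyl result is particular to that group or extends to other branched alkyl groups such as isopropyl. Also open, as far as these compounds go, is whether an amine, a carboxylic acid or a longer chain on this carbon would stay level with hydrogen, fluoro and phenoxy or move the number as tert-butyl does.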